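Cytotoxicity notes on the bicyclic acetal series, chloro to trifluoromethyl

A few compounds are considered here, and "the series" means these few. Any claim that something is new, unique, unknown or untested is made for them only; others in the source may bear on it.

The series shares one core, varied only at the acetal aryl group. Compound 1 `CO[C@@H]1[C@@H](OC)[C@H](c2ccccc2)O[C@@H]2CO[C@@H](Cc3ccccc3)O[C@@H]12` and compound 2 `CO[C@@H]1[C@@H](OC)[C@H](c2ccccc2)O[C@@H]2CO[C@@H](c3ccc(C)cc3)O[C@@H]12` are in hand, but in a functional assay on HEL cells (Homo sapiens) for cytotoxicity (on this read-out higher numbers stand for lower toxicity in this test and lower numbers for higher toxicity in this test), compound 1 gives "not determined" (no result reported) and compound 2 gives "not determined" (no result reported), so neither adds a number. Among the measured compounds shown here, compound 3 `CO[C@@H]1[C@@H](OC)[C@H](c2ccccc2)O[C@@H]2CO[C@@H](c3ccc(Cl)cc3)O[C@@H]12` is the only member with a result in this assay. In this assay compound 3 gives >= 100 ug/mL, which is a limit of the assay rather than a measured number; the context is the limit of >= 100 ug/mL in this assay, at which 1 of the 3 values shown sits.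

Compound 4 `CO[C@@H]1[C@@H](OC)[C@H](c2ccccc2)O[C@@H]2CO[C@@H](c3ccc(C(F)(F)F)cc3)O[C@@H]12` differs from compound 3 in one place: trifluoromethyl in place of chloro on an aromatic carbon. For the measured compounds named here, no measured step between two compounds is available, so there is no pattern to lean on. The change is expected to leave the read-out within the scatter, with no direction beyond it; the step from compound 3 to compound 4 is estimated as a number no higher from compound 3 to compound 4 (the limit leaves the size open). Compound 4 is expected to give 100 ug/mL in this assay, from 50 ug/mL to 200 ug/mL, most likely again as a limit.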

Compound 4, minimum cytotoxic concentration: >= 16 ug/mL
Compound 4: no number, only a limit (the forecaster's own chance of this, stated with the estimate: 75%); the middle value is on the limit's open side.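

In this assay, compound 3 and compound 4 each give only a limit of the assay, so the step between them cannot be read. The compounds shown leave open whether trifluoromethyl in place of chloro on an aromatic carbon shifts the minimum cytotoxic concentration at all.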